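This account rests on a few compounds, and the source may have more. Where it says the series, first, only, none or still open, it means among the compounds named here.

Three compounds have been measured in a functional assay on THP-1 cells (Homo sapiens) for inhibition; on this read-out lower numbers stand for stronger inhibition and higher numbers for weaker inhibition:

Compound 1 `C[C@H](NC(=O)C(=O)NCc1ccccc1)C(=O)N[C@@H](CC(=O)O)C(=O)COc1c(F)c(F)cc(F)c1F`: 160 nM
Compound 2 `C[C@H](NC(=O)C(=O)Nc1ccccc1F)C(=O)N[C@@H](CC(=O)O)C(=O)COc1c(F)c(F)cc(F)c1F`: 160 nM
Compound 3 `C[C@H](NC(=O)C(=O)Nc1ccccc1Cl)C(=O)N[C@@H](CC(=O)O)C(=O)COc1c(F)c(F)cc(F)c1F`: 540 nM

Compound 3 stands at the top of these three numbers. Its distance from the other two is the same in both cases: a 3.4-fold higher number from compound 1 to compound 3 (0.53 log units; beyond the scatter) and a 3.4-fold higher number from compound 2 to compound 3 (0.53 log units; beyond the scatter), both beyond the scatter, whereas no change at the digits printed from compound 1 to compound 2 (within the scatter). All three compounds share the same core and differ only in the group carried on one amide-type nitrogen.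

Compound 4 `C[C@H](NC(=O)C(=O)Nc1cccc2ccccc12)C(=O)N[C@@H](CC(=O)O)C(=O)COc1c(F)c(F)cc(F)c1F` continues at the same position: naphthalen-1-yl in place of 2-chlorophenyl on an amide-type nitrogen. The two steps that end at compound 3 are the only measured ones that bear on it, since both also alter the group on this nitrogen, and both were modest in size. For the measured compounds named here, no measured step exchanges a 2-chlorophenyl for a naphthalen-1-yl, and no measured compound carries two aromatic rings at this nitrogen, so the direction of the step rests on weak ground. Because a 3.4-fold higher number from compound 1 to compound 3 (0.53 log units; beyond the scatter) is the largest change seen so far at this nitrogen and is itself only modest, compound 4 is expected to stay near compound 3, with a 1.5-fold lower number from compound 3 to compound 4 (0.19 log units; within the scatter) as the estimated step. The estimate for compound 4 in this assay is 350 nM, in a range from 90 nM to 1400 nM.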

Compound 4, half-maximal inhibitory concentration: 60 nM
Compound 4: the middle estimate sits 5.8-fold (0.77 log units) above what was measured; the whole stated range lies above it.
By their numbers in this assay, from the lowest: compound 4; then compounds 1 and 2 (each within the scatter of the next); then compound 3.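

In this assay, for the compounds shown here, the result shows that this amide-type nitrogen can carry a bigger aromatic group than any seen in the earlier compounds, since naphthalen-1-yl, with 10 heavy atoms against the 7 of 2-chlorophenyl, gives a 9.0-fold lower number from compound 3 to compound 4 (0.95 log units; beyond the scatter) and so reverses the loss that had come with the chloro group. Going by these compounds alone, the gain also extends past the two best earlier groups, with a 2.7-fold lower number from compound 2 to compound 4 (0.43 log units; beyond the scatter) for the change from 2-fluorophenyl and a 2.7-fold lower number from compound 1 to compound 4 (0.43 log units; beyond the scatter) for the change from benzyl, which puts compound 4 lowest of the four, beyond the scatter of each of the others, where the earlier steps at this nitrogen had only moved the number upward. Nothing in the data explains why this change acts as it does.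

The step from compound 3 to compound 4 removes the chlorine and adds a second ring together, so the part played by each stays unresolved. The compounds shown also leave open how an unsubstituted phenyl, a naphthalen-2-yl or a cyclohexyl on this nitrogen would read in this assay, and whether a second ring helps wherever it is attached.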